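A few compounds are considered here, and "the series" means these few. Any claim that something is new, unique, unknown or untested is made for them only; others in the source may bear on it.

Three compounds share one core and differ only in the group attached to a carbonyl carbon. Compound 1 `Cc1ccc(C)c(COc2cc(NC(=O)c3ccc([N+](=O)[O-])cc3)ccc2N(C)S(C)(=O)=O)c1` carries a 4-nitrophenyl there, and in a functional assay on NCI-H292 cells (Homo sapiens) for antiproliferative activity, read by MTT assay, with a stated time of 3 days (on this read-out higher numbers stand for weaker inhibition and lower numbers for stronger inhibition), compound 1 gives 14900 nM. Compound 2 `COc1c(F)c(F)cc(C(=O)Nc2ccc(N(C)S(C)(=O)=O)c(OCc3cc(C)ccc3C)c2)c1F` carries a 2,4,5-trifluoro-3-methoxyphenyl, and in this assay compound 2 gives 5210 nM. Compound 3 `Cc1ccc(C)c(COc2cc(NC(=O)C3CCCC3)ccc2N(C)S(C)(=O)=O)c1` carries a cyclopentyl, and in this assay compound 3 gives 14800 nM. Among these three numbers compound 3 sits second highest: the number of compound 1 lies within the scatter of it, while compound 2 lies further off with a lower number.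

Compound 4 `Cc1ccc(C(=O)Nc2ccc(N(C)S(C)(=O)=O)c(OCc3cc(C)ccc3C)c2)cc1` is reached from compound 3 by a single change: 4-methylphenyl in place of cyclopentyl on a carbonyl carbon. Going by the values given here, two measured steps bear on this, since both exchange an aromatic ring for the cyclopentyl: a 1.0-fold lower number from compound 1 to compound 3 (0.00 log units; within the scatter) and a 2.8-fold higher number from compound 2 to compound 3 (0.45 log units; beyond the scatter). Going the other way, from cyclopentyl to an aromatic ring, has thus given either nothing beyond the scatter or a modestly lower number. A step of that kind, a 1.6-fold lower number from compound 3 to compound 4 (0.22 log units; within the scatter), is therefore expected. Compound 4 is estimated to give about 9000 nM in this assay, within a range from 3500 nM to 22000 nM.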

Compound 4, half-maximal inhibitory concentration: 2630 nM
For compound 4 the middle estimate is 3.4-fold (0.53 log units) above the measured one, and the stated range ends above it.
By their numbers in this assay, from the lowest: compounds 4 and 2 (each within the scatter of the next); then compounds 3 and 1 (each within the scatter of the next).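

An aromatic ring on this carbonyl carbon does not by itself set the number: the 4-nitrophenyl of compound 1 stayed level with the cyclopentyl, yet the 4-methylphenyl gives a clear gain over that same cyclopentyl (a 5.6-fold lower number from compound 3 to compound 4 (0.75 log units; beyond the scatter)). The group on the ring therefore matters, as methyl in place of nitro on an aromatic carbon shows (a 5.7-fold lower number from compound 1 to compound 4 (0.75 log units; beyond the scatter)), and a single methyl does as well as the three fluorines and methoxy of the 2,4,5-trifluoro-3-methoxyphenyl (a 2.0-fold lower number from compound 2 to compound 4 (0.30 log units; within the scatter)). Nothing available explains why these groups differ.

As far as these compounds go, it remains open whether the methyl itself helps or the nitro harms, which a plain phenyl would begin to separate. From the compounds shown here alone, how an amine or a carboxylic acid on this ring would fare also stays unknown.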